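Methoxy for Methyl on the Aryl Ring of Compound 3

A few compounds are considered here, and "the series" means these few. Any claim that something is new, unique, unknown or untested is made for them only; others in the source may bear on it.

Three compounds share one core and differ at two places. Compound 1 `CC(C)n1nc2c(c1-c1ccccc1)CCNCC2` gives 28 nM in an assay on HEK293 cells for displacement of a labelled ligand from 5-hydroxytryptamine receptor 7 (Rattus norvegicus), read by radioligand binding; a higher number here means a weaker inhibitor, a lower number a stronger inhibitor. Compound 2 `c1ccc(-c2c3c(nn2C2CC2)CCNCC3)cc1` gives 20 nM in this assay, and the step of a 1.4-fold lower number from compound 1 to compound 2 (0.15 log units; within the scatter) lies within the scatter. Compound 3 `Cc1ccc(-c2c3c(nn2C(C)C)CCNCC3)cc1` gives 6 nM, the lowest number of the three and the strongest inhibitor here, with the step of a 4.7-fold lower number from compound 1 to compound 3 (0.67 log units; beyond the scatter) lying beyond the scatter. Compound 4 `COc1ccc(-c2c3c(nn2C(C)C)CCNCC3)cc1` has not been measured; it differs from compound 3 by methoxy in place of methyl on an aromatic carbon. Among the compounds with values here, the only measured step at that position is a 4.7-fold lower number from compound 1 to compound 3 (0.67 log units; beyond the scatter), where methyl replaced hydrogen, so a substituent there is already known to help. Within the data shown here, no measured step exchanges methyl for methoxy, and its size is therefore unknown. One expects compound 4 to stay close to compound 3, with a step of a 1.3-fold higher number from compound 3 to compound 4 (0.12 log units; within the scatter) that may fall within the scatter. Compound 4 is estimated at 8 nM in this assay, in a range from 3 nM to 25 nM.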

Compound 4, inhibition constant: 18 nM
For compound 4 the middle estimate is 2.3-fold (0.35 log units) below the measured one; low and high end bracket the measured number.
By their numbers in this assay, from the lowest: compound 3; then compounds 4, 2 and 1 (each within the scatter of the next).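

On the aromatic carbon para to a large group, the exchange of methyl for methoxy gives a 3.0-fold higher number from compound 3 to compound 4 (0.48 log units; beyond the scatter) in this assay and so shows that the identity of the substituent there matters, not merely its presence. Compared with hydrogen, methoxy gives a 1.6-fold lower number from compound 1 to compound 4 (0.19 log units; within the scatter) while methyl gives a 4.7-fold lower number from compound 1 to compound 3 (0.67 log units; beyond the scatter) and thus only methyl has a gain over hydrogen that stands clear of the scatter. No measurement is available here that would explain this difference between the two groups.

The compounds shown leave open whether chlorine or an ethyl chain on this carbon would give a number closer to that of compound 3 or that of compound 4. They also leave open whether the methoxy step would keep its size with cyclopropyl in place of isopropyl on the aromatic nitrogen.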